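A few compounds are considered here, and "the series" means these few. Any claim that something is new, unique, unknown or untested is made for them only; others in the source may bear on it.

Measured so far in a functional assay on SK-OV-3 cells (Homo sapiens) for inhibition, read by sulforhodamine B assay, with a stated time of 48 h; on this read-out lower numbers stand for stronger inhibition of growth and higher numbers for weaker inhibition of growth:
- Compound 1 `CN(C)/C=C/C(=O)c1nn(-c2ccccc2)c(-c2ccccc2)c1C#N` gives 23800 nM
- Compound 2 `N#Cc1c(-c2nnc(O)c3nn(-c4ccccc4)cc23)nn(-c2ccccc2)c1-c1ccccc1` gives 36800 nM
- Compound 3 `N#Cc1c(-c2nnc(-c3nn(-c4ccccc4)c(-c4ccccc4)c3C#N)c3nn(-c4ccccc4)cc23)nn(-c2ccccc2)c1-c1ccccc1` gives 5720 nM

Compound 3 has the lowest number of the three, and its gaps to compound 1 and compound 2 both lie beyond the scatter. Compound 4 `N#Cc1c(-c2nnc(-c3nn(-c4ccccc4)c(-c4ccccc4)c3C#N)c3nn(-c4ccc(Cl)cc4)cc23)nn(-c2ccccc2)c1-c1ccccc1` differs from compound 3 in one place: it has chloro in place of hydrogen on an aromatic carbon, turning one phenyl into 4-chlorophenyl (chloro in place of hydrogen on an aromatic carbon). For the measured compounds named here, no two measured compounds differ in only one place, so the data offer no direct precedent for this change. The step expected in this assay is a 1.1-fold lower number from compound 3 to compound 4 (0.06 log units; within the scatter) and stays within the scatter. The estimated value for compound 4 is 5000 nM (expected range 2000 nM to 13000 nM).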

Compound 4, concentration for 50% growth inhibition: 36800 nM
The estimate for compound 4 lay 7.4-fold (0.87 log units) below the measured number, outside the stated range (above it).
By their numbers in this assay, from the lowest: compound 3; then compounds 1, 2 and 4 (each within the scatter of the next).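

In this assay, turning one phenyl into 4-chlorophenyl gives a 6.4-fold higher number from compound 3 to compound 4 (0.81 log units; beyond the scatter). For the compounds shown here, this is the first comparison here between compounds that differ in one place, and it shows that adding a single chloro, on an aromatic carbon para to a large group, can weaken growth inhibition beyond the scatter. Nothing available explains this weakening.

As far as these compounds go, whether any group at this place would do the same remains open, since fluoro, methoxy or an amine could behave differently. Also open, from the compounds shown here alone, is how chloro would act on the other phenyl rings.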